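From Benzoyl to 2-Carboxyethyl on the Hydrazide Carbonyl

The source may hold more compounds than are shown below. What is called first, only, known or untested is meant among the compounds shown, and "the series" means these compounds.

Of the compounds shown here, three that share one core have been tested in a functional assay on the whole organism (strain Wistar) for inhibition, with Rattus norvegicus as the target, read by paw edema, with stated times of 30 min and 2 h, at a dose of 20 mg/kg; a lower number here means less inhibition, a higher number more inhibition at the dose given (going by the name of the read-out). Compound 1 `CCOC(=O)C1=C(C)NC(C)=C(C(=O)OCC)C1c1ccc(OCC(=O)Nc2ccc(C)cc2)cc1` gives 62.2%; compound 2 `CCOC(=O)C1=C(C)NC(C)=C(C(=O)OCC)C1c1ccc(OCC(=O)NNC(=O)c2ccccc2)cc1` gives 44.5%; compound 3 `CCOC(=O)C1=C(C)NC(C)=C(C(=O)OCC)C1c1ccc(OCC(=O)NNC(=O)c2ccsc2Cl)cc1` gives 52.8%. Compound 2 stands lowest of the three, with a number 17.7 percentage points lower from compound 1 to compound 2 (beyond the scatter) lying beyond the scatter, while the gap a number 8.3 percentage points higher from compound 2 to compound 3 (within the scatter) sits within it.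

Compound 4 `CCOC(=O)C1=C(C)NC(C)=C(C(=O)OCC)C1c1ccc(OCC(=O)NNC(=O)CCC(=O)O)cc1` is not yet measured. It differs from compound 2 by 2-carboxyethyl in place of phenyl on a carbonyl carbon, a replacement on the same carbonyl carbon that was varied in the step from compound 2 to compound 3. For the measured compounds named here, that earlier step, a number 8.3 percentage points higher from compound 2 to compound 3 (within the scatter), stayed within the scatter, as did a number 9.4 percentage points lower from compound 1 to compound 3 (within the scatter); the only step beyond the scatter, a number 17.7 percentage points lower from compound 1 to compound 2 (beyond the scatter), concerned a different position. Going by the values given here, no measured compound carries an open chain or a carboxylic acid at this place, so the precedent is thin. On the basis of compound 2 alone, a step of a number 2.5 percentage points lower from compound 2 to compound 4 (within the scatter) is expected, no larger than the scatter. Compound 4 is therefore estimated to give 42%, most likely between 28% and 58%.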

Compound 4, a percentage reported as inhibition, in the whole organism at one dose (the size of the read-out at that dose, not a potency): 57.8%
The estimate for compound 4 lay 15.8 percentage points below the measured number; low and high end bracket the measured number.
By their numbers in this assay, from the lowest: compounds 2, 3, 4 and 1 (each within the scatter of the next, the first and the last beyond it).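

In this assay, this carbonyl carbon now shows a step beyond the scatter: 2-carboxyethyl in place of phenyl gives a number 13.3 percentage points higher from compound 2 to compound 4 (beyond the scatter), whereas the earlier replacement here, 2-chlorothiophen-3-yl, stayed within it. An aromatic ring at this place is thus not needed for a number of this size, since the open chain of compound 4 stays within the scatter of both compound 3 and compound 1, with a number 5 percentage points higher from compound 3 to compound 4 (within the scatter) and a number 4.4 percentage points lower from compound 1 to compound 4 (within the scatter). Nothing available explains why the phenyl compound differs from the 2-carboxyethyl compound.

The compounds shown do not separate the part played by the carboxylic acid from that of the open chain, a question that a methyl ester or a plain propyl chain on this carbonyl carbon would address. From the compounds shown here alone, how a longer chain or a terminal amine would read here also remains open.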